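The source may hold more compounds than are shown below. What is called first, only, known or untested is meant among the compounds shown, and "the series" means these compounds.

Three compounds share one core and differ only in the group on the aromatic ring that carries the thiazolidinedione arm. Compound 1 `CC(C)=CCOc1c(C)c(C)c2c(c1C)CCC(C)(COc1ccc(/C=C3\SC(=O)NC3=O)cc1F)O2` bears a fluoro there, and in a functional assay on MCF7 cells (Homo sapiens), tested at 7.5 uM (a lower number here means a stronger effect, a higher number a weaker effect of the compound at the concentration tested), compound 1 gives 64%. Compound 2 `CC(C)=CCOc1c(C)c(C)c2c(c1C)CCC(C)(COc1ccc(/C=C3\SC(=O)NC3=O)cc1-c1ccc(F)cc1)O2` carries a 4-fluorophenyl, and in this assay compound 2 gives 85%. Compound 3 `CCOc1cc(/C=C2\SC(=O)NC2=O)ccc1OCC1(C)CCc2c(C)c(OCC=C(C)C)c(C)c(C)c2O1` carries an ethoxy, and in this assay compound 3 gives 54%. Compound 3 therefore stands at the lowest number of the three; the gap to compound 1 is within the scatter, as a number 10 percentage points lower from compound 1 to compound 3 (within the scatter) shows, while the gap to compound 2 is not, as a number 31 percentage points lower from compound 2 to compound 3 (beyond the scatter) shows.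

Compound 4 `COc1cc(/C=C2\SC(=O)NC2=O)ccc1OCC1(C)CCc2c(C)c(OCC=C(C)C)c(C)c(C)c2O1` differs from compound 3 in one place: hydrogen in place of methyl on a saturated chain carbon bound to an oxygen on an aromatic ring. Among the compounds with values here, none of the measured steps trims an alkyl chain in this way; the steps seen so far swap the whole group on the aromatic ring, with sizes of a number 21 percentage points higher from compound 1 to compound 2 (beyond the scatter) and a number 31 percentage points lower from compound 2 to compound 3 (beyond the scatter), and a change of one carbon on a chain is far smaller than either. No step beyond the scatter is therefore expected in this assay, in either direction, so compound 4 is estimated to give 58%, between 40% and 76%, which means an expected step of a number 4 percentage points higher from compound 3 to compound 4 (within the scatter).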

Compound 4, a percentage reported as activity, at one concentration (the size of the read-out at that concentration, not a potency): 54%
Beside the measured number, compound 4's estimate is 4 percentage points above it, within the range that was stated.
By their numbers in this assay, from the lowest: compounds 3, 4 and 1 (each within the scatter of the next); then compound 2.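

Trimming ethoxy to methoxy gives no change at the digits printed from compound 3 to compound 4 (within the scatter) in this assay, so the outer methyl of the ethoxy group makes no difference that this read-out can detect. Methoxy also behaves as ethoxy did against the other two groups: a number 31 percentage points lower from compound 2 to compound 4 (beyond the scatter) separates it clearly from 4-fluorophenyl, while a number 10 percentage points lower from compound 1 to compound 4 (within the scatter) leaves it indistinguishable from fluoro, so among the four compounds only the 4-fluorophenyl group stands apart. Nothing in the data shown offers a reason for this flat result between the two chains.

The compounds shown leave open whether a longer chain such as butoxy would still read level with methoxy and ethoxy, or whether the weaker effect seen with 4-fluorophenyl extends to other aromatic groups such as plain phenyl. Also open, as far as these compounds go, is how a more different group on this aromatic carbon, such as a hydroxyl, an amine or a carboxylic acid, would read in this assay at the concentration tested.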